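The compounds below may be only part of what the source reports. "The series", "measured", "known", "first", "only" and "open" are said of these compounds alone.

Measured so far:
- compound 1, `O=C(CN1C(=O)c2ccccc2C1=O)NN1C(=O)CSC1c1ccccc1O`: 1.46
- compound 2, `COc1ccc(C2SCC(=O)N2NC(=O)CN2C(=O)c3ccccc3C2=O)cc1`: 1.97

In a physicochemical assay for lipophilicity, in phosphate buffer, measured as octanol-water partition, with a stated time of 24 h (a lower number here means a more polar compound, a higher number a more lipophilic compound), compound 2 gives the higher of the two numbers; compound 1 sits a number 0.51 log units higher from compound 1 to compound 2 (beyond the scatter). Compound 3, `O=C(CN1C(=O)c2ccccc2C1=O)NN1C(=O)CSC1c1cccs1`, has not yet been measured. Its structure departs from compound 2 in one place: thiophen-2-yl in place of 4-methoxyphenyl on a saturated ring carbon. Among the compounds with values here, the one measured step that bears on this is the earlier swap of one aromatic group for another on the same saturated ring carbon, which shifted this assay by a modest amount, a number 0.51 log units higher from compound 1 to compound 2 (beyond the scatter). The present change removes a group bearing a methoxy and puts in a smaller five-membered aromatic ring, so any shift is expected to be small. For compound 3 a value of 1.75 is estimated, within 1.4 to 2.1. That estimate means a step of a number 0.22 log units lower from compound 2 to compound 3 (within the scatter), expected to lie within the usual scatter.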

Compound 3, partition coefficient: 2.15
Compound 3: the middle estimate sits 0.40 log units below what was measured; the measured number lies above the stated range.
By their numbers in this assay, from the lowest: compound 1; then compounds 2 and 3 (each within the scatter of the next).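

In this assay replacing 4-methoxyphenyl with thiophen-2-yl on this saturated ring carbon gives a number 0.18 log units higher from compound 2 to compound 3 (within the scatter) so a smaller five-membered aromatic ring with a sulfur can stand in for the six-membered carbon ring without a step that can be told from the scatter. Set against 2-hydroxyphenyl, thiophen-2-yl gives a number 0.69 log units higher from compound 1 to compound 3 (beyond the scatter) so two different groups have now given a step beyond the scatter when they replace 2-hydroxyphenyl at this position, while compound 2 and compound 3 remain together. Nothing measured here explains these steps.

Still open, on these data alone, is where an amine, a carboxylic acid or a longer chain on this carbon would fall in this assay relative to these three compounds. A plain phenyl group at the same place would also be needed to compare directly with 2-hydroxyphenyl and 4-methoxyphenyl.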